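Halogen moves on the aryl ring of the shared core

The source may report more compounds than this note shows. Statements on the series, on what has been measured and on what is new or still open speak of the compounds shown alone.

The series shares the core of compound 1 `O=C(Nc1ccc(Br)cc1)N[C@H]1CC[C@H](Oc2ccc(F)cc2)CC1`. In a functional assay on CRL2813 cells (Homo sapiens) for cytotoxicity, read by sulforhodamine B assay, with a stated time of 5 days (on this read-out higher numbers stand for weaker inhibition and lower numbers for stronger inhibition), compound 1 reaches only the assay limit, > 20000 nM. Compound 2 `COc1ccccc1NC(=O)N[C@H]1CC[C@H](Oc2ccc(F)cc2)CC1` carries a 2-methoxyphenyl in place of the 4-bromophenyl on the amide-type nitrogen. In this assay compound 2 likewise reaches only the limit, > 20000 nM. Among the measured compounds shown here, compound 3 `O=C(Nc1ccccc1)N[C@H]1CC[C@H](Oc2ccc(F)cc2)CC1` is the one compound with an actual number: in this assay compound 3 gives 20000 nM. The step of a number no higher from compound 1 to compound 3 (the limit leaves the size open) and the step of a number no higher from compound 2 to compound 3 (the limit leaves the size open) are therefore of unknown size, and a step that the two limits leave unreadable from compound 1 to compound 2 cannot be read at all, since the limit of > 20000 nM in this assay, at which 2 of the 3 values shown sit, holds two of the three values.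

Compound 4 `O=C(Nc1cccc(I)c1)N[C@H]1CC[C@H](Oc2ccc(F)cc2)CC1` differs from compound 3 by iodo in place of hydrogen on an aromatic carbon. The nearest measured step, a number no higher from compound 1 to compound 3 (the limit leaves the size open), concerns another halogen at another place on the same ring and gives no readable size, so no step beyond the scatter can be expected in either direction in this assay. Compound 4 is thus expected near 18000 nM with a range of 5000 nM to 60000 nM, which means an estimated step of a 1.1-fold lower number from compound 3 to compound 4 (0.05 log units; within the scatter), and there is a real chance that the assay again returns only a limit.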

Compound 4, half-maximal inhibitory concentration: 5200 nM
The estimate for compound 4 lay 3.5-fold (0.54 log units) above the measured number; low and high end bracket the measured number.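

In this assay, among the compounds shown here, iodo on an aromatic carbon, meta to a large group, gives a 3.8-fold lower number from compound 3 to compound 4 (0.59 log units; beyond the scatter), the only step in these notes with a measured number at both ends and the first sign that this ring responds to substitution at all. The steps of an at least 3.8-fold lower number from compound 2 to compound 4 (0.58 log units; beyond the scatter) and an at least 3.8-fold lower number from compound 1 to compound 4 (0.58 log units; beyond the scatter) point the same way but give only lower bounds on size, because the other end of each is not a number: the limit of > 20000 nM in this assay, at which 2 of the 4 values shown sit. A halogen on this ring does not by itself account for the step, and compound 1, the 4-bromophenyl member, goes against any such reading, since it stays at a limit, > 20000 nM.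

Going by these compounds, with a single iodo compound, the step cannot yet be assigned to iodo itself rather than to the place it occupies, and it remains open whether 3-bromophenyl, 3-chlorophenyl or 3-methylphenyl would behave alike. Equally open, on these data alone, is what a trifluoromethyl group, an amine or a carboxylic acid at the same place would do, and whether the 4-fluorophenoxy end of the shared core tolerates any change alongside the iodo.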